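Rearranging the Bicyclic Ring on the Sulfur

The source may hold more compounds than are shown below. What is called first, only, known or untested is meant among the compounds shown, and "the series" means these compounds.

Compound 2 `CCCCCCCN(CCCCCSc1[nH]cnc2ncnc1-2)C(=O)Nc1ccc(F)cc1F`: 200 nM
Compound 1 `CCCCCCCN(CCCCCSc1ncccn1)C(=O)Nc1ccc(F)cc1F`: 3300 nM

In an assay on microsomes from liver for inhibition of sterol O-acyltransferase 1 (Rattus norvegicus) (a lower number here means a stronger inhibitor, a higher number a weaker inhibitor), compound 2 gives 200 nM, the lowest of the two numbers, while compound 1 gives 3300 nM. Compound 3 `CCCCCCCN(CCCCCSc1[nH]cnc2nncc1-2)C(=O)Nc1ccc(F)cc1F` differs from compound 2 by a group of 9 heavy atoms (5 carbon, 4 nitrogen; one five-membered aromatic ring with 2 hetero atoms, one six-membered aromatic ring with 2 hetero atoms) in place of a group of 9 heavy atoms (5 carbon, 4 nitrogen; one five-membered aromatic ring with 2 hetero atoms, one six-membered aromatic ring with 2 hetero atoms), on a sulfur. For the measured compounds named here, the only measured step, a 17-fold lower number from compound 1 to compound 2 (1.22 log units; beyond the scatter), concerns a different exchange on that sulfur, so no measured step bears directly on this change. Because compound 2 gives 200 nM and the same atoms are merely joined differently, the expected step is a 1.5-fold higher number from compound 2 to compound 3 (0.18 log units; within the scatter), probably within the scatter. Compound 3 is therefore estimated at 300 nM, with a range from 100 nM to 1000 nM.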

Compound 3, half-maximal inhibitory concentration: 710 nM
Beside the measured number, compound 3's estimate is 2.4-fold (0.37 log units) below it, and the stated range covers the measured number.
By their numbers in this assay, from the lowest: compound 2; then compound 3; then compound 1.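

The group on the sulfur is sensitive to more than its atoms: the same atoms joined differently, with the same counts of hydrogen-bond donors and acceptors, still shift the number (a 3.6-fold higher number from compound 2 to compound 3 (0.55 log units; beyond the scatter)). The rearranged bicyclic group keeps an advantage over the single ring (a 4.6-fold lower number from compound 1 to compound 3 (0.67 log units; beyond the scatter)), though a smaller one than compound 2 holds. Nothing measured here explains why the arrangement of these atoms matters.

Going by these compounds, whether a methyl or an amine on the bicyclic group would preserve the number of compound 2 remains open. So does whether a shorter chain on the sulfur would change the gap between the two arrangements.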